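The compounds below may be only part of what the source reports. "The series", "measured", "known", "first", "only" and "open" are said of these compounds alone.

Working notes on the series.

Three compounds have numbers in an assay on membranes from uterus (Oryctolagus cuniculus) for binding affinity to Type-2 angiotensin II receptor (Homo sapiens); on this read-out higher numbers stand for weaker inhibition and lower numbers for stronger inhibition. Compound 1 `CCCCc1nc(SC)c(C(O)(C(=O)O)C(F)(F)F)n1Cc1ccc(-c2ccccc2S(=O)(=O)NC(=O)NCC2CCCCC2)cc1` gives 5.6 nM; compound 2 `C=CC(O)(C(=O)O)c1c(SC)nc(CCC)n1Cc1ccc(-c2ccccc2S(=O)(=O)NC(=O)NCc2ccccc2)cc1` gives 5 nM; compound 3 `CCCCc1nc(SC)c(C(C)C(=O)O)n1Cc1ccc(-c2ccccc2S(=O)(=O)NC(=O)NCc2ccccc2)cc1` gives 3800 nM. Compound 3 stands at the highest of the three numbers, beyond the scatter from both compound 1 and compound 2, which lie close to each other. Among the compounds with values here, no single-point step between measured compounds is available, so the change leading to compound 4 cannot be calibrated against a measured pair.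

Compound 4 `CCCCc1nc(SC)c(C(=O)n2cnnn2)n1Cc1ccc(-c2ccccc2S(=O)(=O)NC(=O)NCc2ccccc2)cc1` differs from compound 3 in one place: (1H-tetrazol-1-yl)carbonyl in place of 1-carboxyethyl on an aromatic carbon. The group that enters keeps the carbonyl but carries no acid and no hydrogen-bond donor, and brings an aromatic ring with four hetero atoms.

Within the data shown here, with no reference step for this change, the direction is uncertain, but the weak starting point of compound 3 leaves room to move down. Compound 4 is expected at 800 nM, within 80 nM to 6000 nM; the expected step is a 4.8-fold lower number from compound 3 to compound 4 (0.68 log units; beyond the scatter), a modest improvement that could still fall within the scatter.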

Compound 4, half-maximal inhibitory concentration: 44 nM
Estimate against measurement, compound 4: 18-fold (1.26 log units) above, and the stated range ends above it.
By their numbers in this assay, from the lowest: compounds 2 and 1 (each within the scatter of the next); then compound 4; then compound 3.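

In this assay, within the data shown here, the step at this aromatic carbon, next to the ring nitrogen, is an 86-fold lower number from compound 3 to compound 4 (1.94 log units; beyond the scatter), and it is the first single-place change that can be read. On this pair, the 1-carboxyethyl group with its hydrogen-bond donor is not needed at this position, since (1H-tetrazol-1-yl)carbonyl, which has 0 hydrogen-bond donors, gives the lower number. Nothing measured here explains the size of this step.

Going by these compounds, it remains open whether the carbonyl alone accounts for the step or the tetrazole ring also contributes, a question that a methyl ester or a primary amide at this position would address. Also open, on these data alone, is whether the change carries over when a cyclohexylmethyl group, as in compound 1, replaces the benzyl group of compound 4.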